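This account rests on a few compounds, and the source may have more. Where it says the series, first, only, none or still open, it means among the compounds named here.

Measured compounds:
compound 1, `O=C(CCc1ccccc1)NNc1c(Cl)cccc1Cl`, 1400 nM
compound 2, `O=C(CCc1ccc(Cl)cc1)NNc1c(Cl)cncc1Cl`, 1100 nM

In a functional assay on HEK293 cells for antagonist activity at P2X purinoceptor 7 (Homo sapiens), read by fluorescence, with a stated time of 2 h (on this read-out lower numbers stand for stronger inhibition and higher numbers for weaker inhibition), compound 1 gives 1400 nM and compound 2 gives 1100 nM. Compound 2 carries the smaller of the two figures, yet the gap to compound 1 lies within the scatter, so the two compounds cannot be told apart on these numbers.

Compound 3, `O=C(CCCC1CCCCC1)NNc1c(Cl)cncc1Cl`, differs from compound 2 in one place: cyclohexylmethyl in place of 4-chlorophenyl on a saturated chain carbon, two bonds along the chain from a carbonyl carbon. Among the measured compounds shown here, no measured pair shows this kind of exchange, so its effect is unknown here. Since the change from compound 1 to compound 2 left the reading within the scatter, the series gives no hint of large swings; a step of roughly the scatter, if anything towards a weaker reading, is the expectation for a 1.5-fold higher number from compound 2 to compound 3 (0.16 log units; within the scatter). Compound 3 is accordingly estimated at 1600 nM, with a range from 500 nM to 5000 nM.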

Compound 3, half-maximal inhibitory concentration: 360 nM
The estimate for compound 3 lay 4.4-fold (0.65 log units) above the measured number; measured number below the stated range.
By their numbers in this assay, from the lowest: compound 3; then compounds 2 and 1 (each within the scatter of the next).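

In this assay the exchange of 4-chlorophenyl for cyclohexylmethyl gives a 3.1-fold lower number from compound 2 to compound 3 (0.49 log units; beyond the scatter) and is the only step shown that lies beyond the scatter. It shows that this place, on a saturated chain carbon, two bonds along the chain from a carbonyl carbon, does not need an aromatic ring or a chlorine for the reading to hold, and that the number can fall when a non-aromatic ring of carbon only stands there. Nothing given here bears on why the number falls with this change.

The single exchange removes the chlorine and the aromatic ring and brings in the methylene link all at once, so the compounds shown do not separate these parts. On these data alone, it also remains open how this place would respond to a cyclohexyl group without the methylene link, a longer chain ending in cyclohexyl, a piperidine ring or a carboxylic acid.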